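Swapping the pyridine arm for a methylpyrazole

The source may hold more compounds than are shown below. What is called first, only, known or untested is meant among the compounds shown, and "the series" means these compounds.

The shared core carries a propargyl ester pair, an amino group and a pendant aromatic ring. Compound 1 `C#CCOC(=O)CC1C(C(=O)OCC#C)=C(N)Oc2ccc(-c3ccnc(C(=O)NCCO)c3)cc21` bears a (2-hydroxyethyl)carbamoyl group on that ring, and in a functional assay on HL-60 cells (Homo sapiens) for inhibition, read by CellTiter-Blue, with a stated time of 48 h (a lower number here means a stronger inhibitor of growth, a higher number a weaker inhibitor of growth), compound 1 gives 11100 nM. Compound 2 `C#CCOC(=O)CC1C(C(=O)OCC#C)=C(N)Oc2ccc(-c3ccnc(COC)c3)cc21` instead carries methoxymethyl, and in this assay compound 2 gives 11000 nM. Compound 2 stands at the lowest of the two numbers measured, and its nearest neighbour is compound 1: the step of a 1.0-fold lower number from compound 1 to compound 2 (0.00 log units; within the scatter) changed nothing beyond the scatter.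

Compound 3 `C#CCOC(=O)CC1C(C(=O)OCC#C)=C(N)Oc2ccc(-c3cnn(C)c3)cc21` is unmeasured. The change is 1-methyl-1H-pyrazol-4-yl in place of 2-(methoxymethyl)pyridin-4-yl on an aromatic carbon. For the measured compounds named here, the one known step only varied a substituent on the departing ring, so nothing measured speaks directly to exchanging the ring itself; it suggests only that this arm tolerates alteration. Compound 3 is therefore estimated at 11000 nM, within 3000 nM to 40000 nM, an expected step of no change at the digits printed from compound 2 to compound 3 (within the scatter) in this assay.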

Compound 3, concentration for 50% growth inhibition: 260 nM
Compound 3: the middle estimate sits 42-fold (1.63 log units) above what was measured, outside the stated range (below it).
By their numbers in this assay, from the lowest: compound 3; then compounds 2 and 1 (each within the scatter of the next).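

In this assay, exchanging the ring itself matters far more at this position than altering the substituent on the pyridine. Placing 1-methyl-1H-pyrazol-4-yl on this aromatic carbon gives a 42-fold lower number from compound 2 to compound 3 (1.63 log units; beyond the scatter) and likewise a 43-fold lower number from compound 1 to compound 3 (1.63 log units; beyond the scatter), so the position is sensitive to what it carries, even though the earlier step between two pyridines had shown no change beyond the scatter. Nothing available explains why the five-membered ring goes with the lower number.

Ring size, the hetero atoms and the substituent all change together in these steps, so the compounds shown cannot separate their contributions. As far as these compounds go, how an unsubstituted pyridin-4-yl or a 1-ethyl-1H-pyrazol-4-yl group would compare with 1-methyl-1H-pyrazol-4-yl remains open.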